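Compound 3: a new group on the carbonyl carbon

The compounds below may be only part of what the source reports. "The series", "measured", "known", "first", "only" and "open" are said of these compounds alone.

Values in an ADME assay on microsomes from liver (Homo sapiens) for metabolic stability, with a stated time of 10 min (on this read-out higher numbers stand for a more stable compound and lower numbers for a less stable compound), so far

- compound 1 (`O=C(N1CCOCC1)N1CC[C@](c2ccc(C(OCc3c(F)cccc3F)(C(F)(F)F)C(F)(F)F)cc2)(S(=O)(=O)c2ccc(F)cc2)C1`) gives 3%
- compound 2 (`CC(=O)N1CCN(C(=O)N2CC[C@](c3ccc(C(OCc4c(F)cccc4F)(C(F)(F)F)C(F)(F)F)cc3)(S(=O)(=O)c3ccc(F)cc3)C2)CC1`) gives 5%

Among the measured compounds shown here, compound 2 stands within the scatter of compound 1, the only other compound measured, and little of either remains at the end of the test. The next compound, compound 3 (`O=C(O)C1CCN(C(=O)N2CC[C@](c3ccc(C(OCc4c(F)cccc4F)(C(F)(F)F)C(F)(F)F)cc3)(S(=O)(=O)c3ccc(F)cc3)C2)CC1`), keeps the shared core and changes one group: 4-carboxypiperidin-1-yl in place of 4-acetylpiperazin-1-yl on a carbonyl carbon.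

For the measured compounds named here, one measured step bears on this, made on the same kind of carbonyl carbon, and it is a number 2 percentage points higher from compound 1 to compound 2 (within the scatter) for 4-acetylpiperazin-1-yl in place of morpholin-4-yl. That step is a weak guide: neither compound 1 nor compound 2 carries a carboxy group. With compound 2 at 5% there is hardly any room downward, so a rise beyond the scatter is expected. The step expected in this assay is a number 35 percentage points higher from compound 2 to compound 3 (beyond the scatter) and its size is quite uncertain. For compound 3 the estimated value is 40% with a range from 10% to 85% as the expected span.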

Compound 3, percent of the compound remaining: 72%
Estimate against measurement, compound 3: 32 percentage points below, and the stated range covers the measured number.
By their numbers in this assay, from the lowest: compounds 1 and 2 (each within the scatter of the next); then compound 3.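

The group on the carbonyl carbon turns out to matter strongly in this assay, which the first two compounds, lying within the scatter of each other, gave no sign of: 4-carboxypiperidin-1-yl in place of 4-acetylpiperazin-1-yl gives a number 67 percentage points higher from compound 2 to compound 3 (beyond the scatter), and 4-carboxypiperidin-1-yl in place of morpholin-4-yl gives a number 69 percentage points higher from compound 1 to compound 3 (beyond the scatter). The change is also a small one on paper, since 4-acetylpiperazin-1-yl and 4-carboxypiperidin-1-yl both hold 9 heavy atoms and one six-membered non-aromatic ring, while 4-carboxypiperidin-1-yl carries 1 hydrogen-bond donor and 4-acetylpiperazin-1-yl carries 0. Nothing available here explains why so modest a swap goes with so large a rise.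

In 4-carboxypiperidin-1-yl the carboxy group and the loss of a ring nitrogen arrive together, so the compounds shown cannot tell which of the two goes with the higher number. A methyl ester or a primary amide in place of the carboxylic acid on the same piperidine ring, or a carboxylic acid on a longer chain, would help to show whether the free acid itself is what counts.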